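A few compounds are considered here, and "the series" means these few. Any claim that something is new, unique, unknown or untested is made for them only; others in the source may bear on it.

Acid ceramidase is an enzyme, and this study measures how well small molecules block it in an assay on isolated protein for inhibition of acid ceramidase (Homo sapiens), read by LC-MS, with a stated time of 1 h; a lower number here means a stronger inhibitor, a higher number a weaker inhibitor. Compound 1 has the structure `O=C(NCCCCc1ccccc1)n1c(-c2ccccc2)coc1=O` and in this assay gives 70 nM. Compound 2, `CCCCCNC(=O)n1c(-c2ccccc2)coc1=O`, differs from compound 1 by methyl in place of phenyl on a saturated chain carbon, four bonds along the chain from an amide-type nitrogen. In this assay compound 2 gives 25 nM; that single change made a 2.8-fold lower number from compound 1 to compound 2 (0.45 log units; beyond the scatter). Compound 3, `CN1CCC(c2cc(-c3cn(C(=O)NCCCCc4ccccc4)c(=O)o3)ccc2F)CC1`, is built on a different core; how the core of compound 3 differs from the core of compound 1 is not broken down here. In this assay compound 3 gives 341 nM, the highest of the three numbers, so it is the weakest inhibitor of the three. Compound 4, `CCCCCNC(=O)n1cc(-c2ccc(F)c(C3CCN(C)CC3)c2)oc1=O`, is still to be measured; it differs from compound 3 by methyl in place of phenyl on a saturated chain carbon, four bonds along the chain from an amide-type nitrogen, the same change that separates compound 1 from compound 2, made at the same place. The step expected from compound 3 to compound 4 is a 2.6-fold lower number from compound 3 to compound 4 (0.42 log units; beyond the scatter), resting on a single earlier example, because a 2.8-fold lower number from compound 1 to compound 2 (0.45 log units; beyond the scatter) was the outcome when the same change was made on the other core. Compound 4 is therefore estimated at 130 nM, with a plausible range from 60 nM to 280 nM.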

Compound 4, half-maximal inhibitory concentration: 1920 nM
For compound 4 the middle estimate is 15-fold (1.17 log units) below the measured one; the whole stated range lies below it.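

Replacing the phenyl at the end of the chain with a methyl gave a 5.6-fold higher number from compound 3 to compound 4 (0.75 log units; beyond the scatter), so on this core the shorter chain gives the weaker inhibitor. In this assay the change therefore does not carry from one core to the other, in size or in direction: the same change on two cores in this assay, a 2.8-fold lower number (0.45 log units; beyond the scatter) from compound 1 to compound 2 and a 5.6-fold higher number (0.75 log units; beyond the scatter) from compound 3 to compound 4, 16-fold (1.20 log units) apart, beyond the scatter of two such steps. Among these compounds, this shows that the effect of the change depends on the core it is made on, so a step seen on one core is a poor guide to the step on the other; it does not show which feature of the core is responsible or give a rule for other cores, with only one pair of compounds on each core.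

The compounds shown leave open which part of the difference between the cores turns the step around. They also leave open how a longer chain, or a chain ending in an amine or a carboxylic acid, would behave on each core.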